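The source may report more compounds than this note shows. Statements on the series, on what has been measured and on what is new or still open speak of the compounds shown alone.

Compound 1, `O=C(NC/C=C1\CCCc2cnn(Cc3ccc(Cl)cc3Cl)c21)NS(=O)(=O)c1ccc(Cl)cc1`, gives 4 nM in an assay on isolated protein for displacement of a labelled ligand from prostaglandin E2 receptor EP3 subtype (Homo sapiens), read by scintillation counting, with a stated time of 2 h; a lower number here means a stronger inhibitor, a higher number a weaker inhibitor.
Compound 2, `Cn1cc(S(=O)(=O)NC(=O)NC/C=C2\CCCc3cnn(Cc4ccc(Cl)cc4Cl)c32)cn1`, gives 9 nM in this assay.

Within the data shown here, compound 2 stands at the higher of the two numbers, and the only measured step, a 2.3-fold higher number from compound 1 to compound 2 (0.35 log units; beyond the scatter), is modest. Compound 3, `Cc1ncc(S(=O)(=O)NC(=O)NC/C=C2\CCCc3cnn(Cc4ccc(Cl)cc4Cl)c32)s1`, differs from compound 2 by 2-methyl-1,3-thiazol-5-yl in place of 1-methyl-1H-pyrazol-4-yl on a sulfonyl sulfur. No measured step covers this change: the one step shown swaps a different ring on the sulfonyl sulfur, so it bears on it only loosely. Compound 3 is therefore expected to stay close to compound 2, with a 1.1-fold lower number from compound 2 to compound 3 (0.05 log units; within the scatter). Compound 3 is estimated at 8 nM, within 3 nM to 25 nM.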

Compound 3, inhibition constant: 7 nM
For compound 3 the middle estimate is 1.1-fold (0.06 log units) above the measured one; low and high end bracket the measured number.
By their numbers in this assay, from the lowest: compounds 1, 3 and 2 (each within the scatter of the next, the first and the last beyond it).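

On the sulfonyl sulfur, 2-methyl-1,3-thiazol-5-yl can replace 1-methyl-1H-pyrazol-4-yl in this assay with little consequence, giving a 1.3-fold lower number from compound 2 to compound 3 (0.11 log units; within the scatter). Set against the 4-chlorophenyl group, the thiazole shows a 1.8-fold higher number from compound 1 to compound 3 (0.24 log units; within the scatter), so this swap stays within the scatter, which the pyrazole swap did not. Nothing at hand explains this difference.

Still open, on these data alone, is whether an open-chain group such as methyl or a longer alkyl chain on the sulfonyl sulfur would fit as well. So is the effect of an amine or a carboxylic acid on the ring there.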